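This account rests on a few compounds, and the source may have more. Where it says the series, first, only, none or still open, it means among the compounds named here.

Compound 1 `CCCCN1CCC(CNC(=O)c2cc(Br)cc3[nH]cnc23)CC1`, in an assay on membranes from striatum for binding affinity to 5-hydroxytryptamine receptor 4 (Rattus norvegicus); a higher number here means a weaker inhibitor, a lower number a stronger inhibitor: 0.64 nM
Compound 2 `CCCCN1CCC(CNC(=O)c2cc(Cl)c([N+](=O)[O-])c3[nH]cnc23)CC1`, in this assay: 44.6 nM

Within the data shown here, compound 2 has the higher of the two numbers measured so far; compound 1 sits well below it, and the gap is beyond the scatter of repeated measurements. Compound 3 `CCCCN1CCC(CNC(=O)c2cc(Br)c([N+](=O)[O-])c3[nH]cnc23)CC1` has not yet been measured in this assay. It differs from compound 2 by bromo in place of chloro on an aromatic carbon. Among the measured compounds shown here, no measured pair shows this exchange, so the expected step is none beyond the scatter, in either direction. The expected value for compound 3 in this assay is 38 nM, with a range of 13 nM to 110 nM. The estimated step is a 1.2-fold lower number from compound 2 to compound 3 (0.07 log units; within the scatter).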

Compound 3, inhibition constant: 48.2 nM
Beside the measured number, compound 3's estimate is 1.3-fold (0.10 log units) below it; measured number inside the range.
By their numbers in this assay, from the lowest: compound 1; then compounds 2 and 3 (each within the scatter of the next).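

In this assay, bromo in place of chloro on the aromatic carbon ortho to a nitro group gives a 1.1-fold higher number from compound 2 to compound 3 (0.03 log units; within the scatter) and so does not separate the two halogens in this setting. Nitro in place of hydrogen gives a 75-fold higher number from compound 1 to compound 3 (1.88 log units; beyond the scatter) as the one large single-place change in the series, which places the loss of affinity with the nitro group rather than the halogen. Nothing measured here gives a reason for either step.

Going by these compounds, it remains open whether an amine or a methoxy group in place of the nitro group would stay near compound 1. Whether chloro and bromo also match without the nitro group is open too.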